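The compounds below may be only part of what the source reports. "The series", "measured", "known", "first", "only" and "open" are said of these compounds alone.

Compound 1 `COc1ccc(OC)c(/C=N/NC(=O)Nc2ccc(Oc3ccnc(-c4nncn4CCN(C)C)c3)c(F)c2)c1`: in a functional assay on MKN-45 cells (Homo sapiens) for cytotoxicity, read by MTT assay, with a stated time of 72 h (a lower number here means a stronger inhibitor, a higher number a weaker inhibitor), compound 1 gives 1510 nM.
Compound 2 `CN(C)CCn1cnnc1-c1cc(Oc2ccc(NC(=O)N/N=C/c3ccccc3)cc2F)ccn1`: compound 2 gives 2730 nM.
Compound 3 `CN(C)CCn1cnnc1-c1cc(Oc2ccc(NC(=O)N/N=C/c3ccc(Cl)cc3)cc2F)ccn1`: compound 3 gives 570 nM.

Among these three numbers compound 1 stands second highest; its nearest neighbour is compound 2, with a 1.8-fold higher number from compound 1 to compound 2 (0.26 log units; within the scatter), while its furthest is compound 3, with a 2.6-fold lower number from compound 1 to compound 3 (0.42 log units; beyond the scatter). Compound 4 `CN(C)CCn1cnnc1-c1cc(Oc2ccc(NC(=O)N/N=C/c3ccc(O)c(F)c3)cc2F)ccn1` differs from compound 1 at one spot only: 3-fluoro-4-hydroxyphenyl in place of 2,5-dimethoxyphenyl on a carbon with a double bond to nitrogen. Among the compounds with values here, no measured step brings in this exact group. Within the data shown here, the only guidance comes from the changes made on the same carbon, the two steps just named plus a 4.8-fold lower number from compound 2 to compound 3 (0.68 log units; beyond the scatter), none of them larger than modest. The expected step of a 1.0-fold lower number from compound 1 to compound 4 (0.00 log units; within the scatter) is therefore estimated as none beyond the scatter, with no firm direction. Compound 4 is expected to give 1500 nM, within 500 nM to 4500 nM.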

Compound 4, half-maximal inhibitory concentration: 1970 nM
Beside the measured number, compound 4's estimate is 1.3-fold (0.12 log units) below it; the range from low to high includes it.
By their numbers in this assay, from the lowest: compound 3; then compounds 1, 4 and 2 (each within the scatter of the next).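

In this assay, a ring carrying a hydrogen-bond donor, 3-fluoro-4-hydroxyphenyl, stays within the scatter of both 2,5-dimethoxyphenyl (a 1.3-fold higher number from compound 1 to compound 4 (0.12 log units; within the scatter)) and plain phenyl (a 1.4-fold lower number from compound 2 to compound 4 (0.14 log units; within the scatter)). Among these four compounds, only the 4-chlorophenyl group stands apart (a 3.5-fold higher number from compound 3 to compound 4 (0.54 log units; beyond the scatter)), so at this position, a fluorine together with a hydroxyl does not match the single chloro. No measurement shown explains this difference. Still open, going by these compounds, is whether a bromo, a methyl or an amine in the place of that chloro would match compound 3.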